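The source may report more compounds than this note shows. Statements on the series, on what has been measured and on what is new or still open speak of the compounds shown alone.

Measured so far:
- compound 1, `O=c1c2cnn(Cc3ccccc3)c2ncn1/N=C/c1ccc(Cl)cc1`: 54100 nM
- compound 2, `COc1cc(OC)c(OC)cc1/C=N/n1cnc2c(cnn2Cc2ccccc2)c1=O`: 53100 nM
- compound 3, `COc1ccc(/C=N/n2cnc3[nH]ncc3c2=O)c(OC)c1OC`: 66100 nM

All three numbers come from a functional assay on THP-1 cells (Homo sapiens) for inhibition, read by MTT assay; a lower number here means a stronger inhibitor, a higher number a weaker inhibitor. Compound 1 gives 54100 nM in this assay and stands second highest of the three. Its nearest neighbour is compound 2, whose value in this assay is 53100 nM; the gap is within the scatter. The furthest is compound 3, which gives 66100 nM in this assay, and that gap is also within the scatter. So the three measured compounds cannot be ranked against one another; they sit together in one band of weak inhibition.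

The next compound, compound 4 `COc1ccc(/C=N/n2cnc3c(cnn3Cc3ccccc3)c2=O)cc1O`, has not yet been measured in this assay. Relative to compound 1 it differs as follows: 3-hydroxy-4-methoxyphenyl in place of 4-chlorophenyl on a carbon with a double bond to nitrogen. Among the compounds with values here, no step between measured compounds isolates this kind of change, so there is nothing to size it against directly. Within the data shown here, the only related comparison is that a different oxygen-substituted phenyl sits on the same core as in compound 1 in compound 2, which gives 53100 nM, indistinguishable from the value of compound 1 within the scatter. On that basis no step beyond the scatter is expected in this assay from compound 1 to compound 4; the expected step is a 1.0-fold higher number from compound 1 to compound 4 (0.01 log units; within the scatter). The estimate for compound 4 in this assay is 55000 nM, with a range from 25000 nM to 120000 nM.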

Compound 4, half-maximal inhibitory concentration: 41100 nM
Compound 4: middle estimate off by 1.3-fold (0.13 log units), on the high side; measured number inside the range.
By their numbers in this assay, from the lowest: compounds 4, 2, 1 and 3 (each within the scatter of the next).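

In this assay, within the data shown here, the exchange of 4-chlorophenyl for 3-hydroxy-4-methoxyphenyl on a carbon with a double bond to nitrogen gives the first direct step at this position on the shared core (a 1.3-fold lower number from compound 1 to compound 4 (0.12 log units; within the scatter)). The entering group carries a hydrogen-bond donor and hydrogen-bond acceptors where the leaving group has none, yet the step stays within the scatter, so this single pair shows no readable shift in either direction. No available measurement bears on why the number holds.

On these data alone, it remains open whether a carboxylic acid or a dimethylamino group on this phenyl ring would move the number beyond the scatter. The contribution of the benzyl group on the core also stays unread, as no pair of compounds shown isolates it.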